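Compound 3: Methoxy in Place of Methyl

The source may hold more compounds than are shown below. What is called first, only, known or untested is meant among the compounds shown, and "the series" means these compounds.

Measured in a functional assay on K562 cells (Homo sapiens) for inhibition, read by sulforhodamine B assay, with a stated time of 48 h; on this read-out higher numbers stand for weaker inhibition of growth and lower numbers for stronger inhibition of growth:
Compound 1 `CC(C)(C)NCc1c(C(=O)O)nn(-c2ccccc2)c1-c1ccc(Br)cc1`: > 585000 nM, a limit
Compound 2 `Cc1ccc(-c2c(CNC(C)(C)C)c(C(=O)O)nn2-c2ccccc2)cc1`: > 688000 nM, a limit

Compound 2 stands at > 688000 nM, which is a limit. Compound 3 `COc1ccc(-c2c(CNC(C)(C)C)c(C(=O)O)nn2-c2ccccc2)cc1` carries methoxy in place of methyl on an aromatic carbon. For the measured compounds named here, the one measured step, a step that the two limits leave unreadable from compound 1 to compound 2, bears on this change, but it gives no size to carry over. The step expected in this assay is an at least 1.0-fold lower number from compound 2 to compound 3 (0.01 log units; that floor lies within the scatter), none beyond the scatter and with no set direction. Compound 3 is expected to be reported as a limit as well. For compound 3 the estimate is 660000 nM, with an expected range of 350000 nM to 900000 nM.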

Compound 3, concentration for 50% growth inhibition: > 659000 nM
Compound 3 ended at the assay's limit; the forecaster's own chance of this, stated with the estimate: 85%; the middle value is on the limit's open side.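

For the compounds shown here, compound 1, compound 2 and compound 3 all stand as limits in this assay, and no step among them can be read. The compounds shown leave open how bromo, methyl and methoxy on this aromatic carbon compare.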